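A few compounds are considered here, and "the series" means these few. Any claim that something is new, unique, unknown or untested is made for them only; others in the source may bear on it.

Measured compounds:
- compound 1, `C=C1CCS(=O)(=O)c2cc(C(=O)N=C(N)N)c(C)cc21`: 29 nM
- compound 2, `Cc1cc2c(cc1C(=O)N=C(N)N)S(=O)(=O)CC2C`: 44 nM
- compound 3, `Cc1cc2c(cc1C(=O)N=C(N)N)S(=O)(=O)C/C2=N\O`: 16 nM

All three share one core and were tested in an assay on cells for inhibition of sodium/hydrogen exchanger (Oryctolagus cuniculus); a higher number here means a weaker inhibitor, a lower number a stronger inhibitor. Compound 3 gives 16 nM, the lowest of the three numbers. Compound 1 gives 29 nM, and this gap to compound 3 lies within the usual scatter, so nothing can be said about which of the two is the stronger inhibitor. Compound 2 gives 44 nM, which lies beyond the scatter, so compound 3 is a stronger inhibitor than compound 2.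

Compound 4, `CO/N=C1\CS(=O)(=O)c2cc(C(=O)N=C(N)N)c(C)cc21`, has not yet been measured. It differs from compound 3 in one place: methyl in place of hydrogen on an oxygen. The hydroxy of compound 3 becomes a methoxy in compound 4.

There is no measured pair that shows this change, so the expectation rests on the spread of the three numbers shown. Compound 1 and compound 2, which carry neither a hydroxy nor a methoxy, sit near compound 3, and the step from compound 3 to compound 4 is therefore expected to be small, most likely a modest rise or none beyond the scatter: a 1.6-fold higher number from compound 3 to compound 4 (0.19 log units; within the scatter). For compound 4 the estimated value in this assay is 25 nM, with a range from 10 nM to 60 nM.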

Compound 4, half-maximal inhibitory concentration: 45 nM
Estimate against measurement, compound 4: 1.8-fold (0.26 log units) below, and the stated range covers the measured number.
By their numbers in this assay, from the lowest: compounds 3, 1, 2 and 4 (each within the scatter of the next, the first and the last beyond it).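

Turning the hydroxy into a methoxy gives a 2.8-fold higher number from compound 3 to compound 4 (0.45 log units; beyond the scatter) in this assay, the first measured step here that changes one place only, and it lies beyond the usual scatter. It shows that this oxygen is not indifferent to what it carries: adding a single methyl in place of the hydrogen weakens inhibition, although compound 4 at 45 nM remains an inhibitor in the nanomolar range. Nothing measured on these compounds explains why this step raises the number.

From the compounds shown here alone, one step cannot separate the loss of the hydrogen from the arrival of the methyl, so it remains open which of the two matters. An ethoxy or a longer chain on the same oxygen could show whether the number keeps rising as the group grows, while a carboxylic acid or an amine at the end of such a chain could show whether the kind of group counts as well as its size.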